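Aryl variation on the amine-side benzyl group

The source may report more compounds than this note shows. Statements on the series, on what has been measured and on what is new or still open speak of the compounds shown alone.

Measured compounds:
compound 1 `O=S(=O)(NCCCNCc1cccc2ccccc12)c1cc(C(F)(F)F)cc(C(F)(F)F)c1` gives 2700 nM in a functional assay on BXPC-3 cells (Homo sapiens) for inhibition, read by MTT assay, with a stated time of 72 h; a lower number here means a stronger inhibitor of growth, a higher number a weaker inhibitor of growth
compound 2 `O=S(=O)(NCCCNCC1COc2ccccc2O1)c1cc(C(F)(F)F)cc(C(F)(F)F)c1` gives 1200 nM in this assay
compound 3 `COc1ccccc1CNCCCNS(=O)(=O)c1cc(C(F)(F)F)cc(C(F)(F)F)c1` gives 1700 nM in this assay

Compound 3 stands second highest of the three values; it is nearest compound 2, a step within the scatter, and furthest from compound 1, a 1.6-fold lower number from compound 1 to compound 3 (0.20 log units; within the scatter), also within the scatter. The unmeasured compound 4 `O=S(=O)(NCCCNCc1ccc(Br)cc1)c1cc(C(F)(F)F)cc(C(F)(F)F)c1` differs from compound 3 in one place: 4-bromophenyl in place of 2-methoxyphenyl on a saturated chain carbon bound to an amine nitrogen.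

All three measured steps change the same aryl group on the saturated chain carbon bound to the amine nitrogen and therefore bear on this one. The largest, a 2.3-fold lower number from compound 1 to compound 2 (0.35 log units; beyond the scatter), is modest; the others, a 1.6-fold lower number from compound 1 to compound 3 (0.20 log units; within the scatter) and a 1.4-fold higher number from compound 2 to compound 3 (0.15 log units; within the scatter), stay within the scatter. Exchanging one aromatic group for another at this place has so far moved this assay little, so for compound 4 a step of the size a 1.1-fold higher number from compound 3 to compound 4 (0.02 log units; within the scatter) is expected, in no direction beyond the scatter, and compound 4 is estimated at 1800 nM with a range from 800 nM to 4000 nM.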

Compound 4, concentration for 50% growth inhibition: 1500 nM
Compound 4: middle estimate off by 1.2-fold (0.08 log units), on the high side; low and high end bracket the measured number.
By their numbers in this assay, from the lowest: compounds 2, 4, 3 and 1 (each within the scatter of the next, the first and the last beyond it).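

In this assay, replacing 2-methoxyphenyl with 4-bromophenyl removes the one hydrogen-bond acceptor of the group and brings in bromine, yet the step stays within the scatter (a 1.1-fold lower number from compound 3 to compound 4 (0.05 log units; within the scatter)). The other two steps to compound 4 also stay within the scatter (a 1.3-fold higher number from compound 2 to compound 4 (0.10 log units; within the scatter); a 1.8-fold lower number from compound 1 to compound 4 (0.26 log units; within the scatter)), so at this place on a saturated chain carbon bound to an amine nitrogen, the 4-bromophenyl group is not separated from any of the three earlier groups. No measurement is available here that would account for this flat response.

The compounds shown leave open whether a group without an aromatic ring, such as a cyclohexyl group, or one carrying a carboxylic acid or a second amine, would hold these values in this assay. Also open, on these data alone, are 2-bromophenyl as the direct partner of 4-bromophenyl and a longer chain in the shared core.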